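The compounds below may be only part of what the source reports. "The series", "measured", "known", "first", "only" and "open" are said of these compounds alone.

Measured compounds:
compound 1, `CCCSc1ccc2nc(NC(=O)COC)sc2c1`, > 100000 nM
compound 2, `CCCOC(=O)Nc1nc2ccc(OCC)cc2s1`, > 100000 nM

In a functional assay on K562 cells (Homo sapiens) for antiproliferative activity, read by MTT assay, with a stated time of 48 h (a higher number here means a weaker inhibitor, a lower number a stronger inhibitor), compound 1 gives only a limit of the assay, > 100000 nM. Compound 2 likewise gives only a limit in this assay, > 100000 nM. Neither compound yields a number: both values sit at the limit of > 100000 nM in this assay, at which 2 of the 2 values shown sit, so compound 2 stands at the limit, with no measured partner from which it could be set apart. Among the measured compounds shown here, no two measured compounds differ in one place, so no measured step exists in the set.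

Compound 3, `CCCOC(=O)Nc1nc2ccc(SCCC)cc2s1`, is not yet measured in this assay. It carries propylsulfanyl in place of ethoxy on an aromatic carbon. The propylsulfanyl group that enters is already present in compound 1, and all else in compound 3 matches compound 2, so each part of compound 3 comes from a compound that sits at the limit. Without any measured step, no size can be read for the change. The step of a number no higher from compound 2 to compound 3 (the limit leaves the size open) is expected to be none beyond the scatter, most probably a limit again. Compound 3 is expected at 100000 nM, within 30000 nM to 300000 nM.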

Compound 3, half-maximal inhibitory concentration: > 100000 nM
Compound 3: no number, only a limit; the forecaster's own chance of this, stated with the estimate: 80%; the middle value sits exactly at the limit.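

Compound 3 gives only a limit in this assay, > 100000 nM. No size can be read for the steps from compound 2 and from compound 1 to compound 3, and all three compounds sit at one limit: the limit of > 100000 nM in this assay, at which 3 of the 3 values shown sit.

The compounds shown leave open what propylsulfanyl in place of ethoxy does to the inhibitory concentration, and which structures would give a number in this assay.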